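The source may report more compounds than this note shows. Statements on the series, on what has been measured and on what is new or still open speak of the compounds shown alone.

Measured in a functional assay on BMEC cells (Bos taurus) for antiproliferative activity; a higher number here means a weaker inhibitor, a lower number a stronger inhibitor:
Compound 1 `COc1cc(/C=C\Cc2cc(O)c3ccsc3c2)cc(OC)c1OC`: 87 nM
Compound 2 `COc1cc(/C=C\Cc2cc(O)c3cc(C)sc3c2)cc(OC)c1OC`: 23 nM
Compound 3 `COc1cc(/C=C\Cc2cc(O)c3cc(-c4ccccc4)sc3c2)cc(OC)c1OC`: 23000 nM

The middle place among these three numbers belongs to compound 1. Its neighbours are reached by a 3.8-fold lower number from compound 1 to compound 2 (0.58 log units; beyond the scatter) and by a 260-fold higher number from compound 1 to compound 3 (2.42 log units; beyond the scatter).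

The unmeasured compound 4 `COc1cc(/C=C\Cc2cc(OP(=O)(O)O)c3ccsc3c2)cc(OC)c1OC` keeps the core of compound 1 and carries one change: a group of 4 heavy atoms (3 oxygen, 1 phosphorus; no ring) in place of a hydrogen atom, on an oxygen on an aromatic ring. Among the compounds with values here, no measured compound is altered at that oxygen, so the data hold no direct precedent. The two steps above, together with a 1000-fold higher number from compound 2 to compound 3 (3.00 log units; beyond the scatter), all concern an aromatic carbon and bear on this change only indirectly. They show that a single substitution on this core can leave the number within a modest distance or move it a long way, so the range has to stay wide. A small step towards a higher number is expected, though this rests on little evidence. The step expected is a 1.7-fold higher number from compound 1 to compound 4 (0.24 log units; within the scatter). For compound 4 the estimated value is 150 nM, with an expected range of 30 nM to 1000 nM.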

Compound 4, half-maximal inhibitory concentration: 640 nM
For compound 4 the middle estimate is 4.3-fold (0.63 log units) below the measured one; the measured number falls inside the stated range.
By their numbers in this assay, from the lowest: compound 2; then compound 1; then compound 4; then compound 3.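

In this assay, placing a group of 4 heavy atoms (3 oxygen, 1 phosphorus) on this oxygen on an aromatic ring gives a 7.4-fold higher number from compound 1 to compound 4 (0.87 log units; beyond the scatter) and so shows that a change at this oxygen, not only at the aromatic carbon, moves the number beyond the scatter. This step runs in the same direction as a 260-fold higher number from compound 1 to compound 3 (2.42 log units; beyond the scatter) but is much shorter, and it runs against a 3.8-fold lower number from compound 1 to compound 2 (0.58 log units; beyond the scatter) on the same core. Nothing available here accounts for the rise at this oxygen.

The compounds shown leave open whether a smaller group on this oxygen, such as a methyl ether or an acetate, would give a step of similar size. They also leave open how the same phosphate-type group would act on the methyl-bearing core of compound 2.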